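The source may hold more compounds than are shown below. What is called first, only, known or untested is meant among the compounds shown, and "the series" means these compounds.

Compound 2 `C[C@]1(O)C[C@](c2cc(C(F)(F)F)ccn2)([C@@H](O)c2ccccn2)C1` stands at the limit of an assay on HEK293 cells for antagonist activity at transient receptor potential cation channel subfamily V member 3 (Homo sapiens), read by FLIPR and calcium flux; on this read-out lower numbers stand for stronger inhibition and higher numbers for weaker inhibition: compound 2 gives > 9100 nM, a limit and not a number. Compound 3 `C[C@]1(O)C[C@](c2cc(C(F)(F)F)ccn2)([C@H](O)c2ccccn2)C1` is reached from compound 2 by the two compounds have the same atoms and bonds and differ only in configuration as drawn: 2 of 3 stereo elements differ; a stereocentre at a saturated ring carbon is drawn R in compound 2 and S in compound 3; a stereocentre at a saturated chain carbon is drawn R in compound 2 and S in compound 3. Within the data shown here, the only measured step of this kind is an at least 12-fold higher number from compound 1 to compound 2 (1.09 log units; beyond the scatter), which ends at the limit of > 9100 nM in this assay, at which 1 of the 2 values shown sits, and rests on (the fact that compounds 1 and 2 differ only in the configuration as drawn); compound 1 `C[C@]1(O)C[C@@](c2cc(C(F)(F)F)ccn2)([C@H](O)c2ccccn2)C1` gives 730 nM in this assay. Compound 3 shares part of its configuration with compound 1 and part with compound 2, so a step of an at least 3.0-fold lower number from compound 2 to compound 3 (0.48 log units; beyond the scatter) toward a lower number is expected, with wide uncertainty. Compound 3 is estimated at 3000 nM, between 700 nM and 15000 nM.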

Compound 3, antagonist equilibrium constant: 560 nM
Estimate against measurement, compound 3: 5.4-fold (0.73 log units) above, outside the stated range (below it).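

The step of a 1.3-fold lower number from compound 1 to compound 3 (0.12 log units; within the scatter) shows that compounds 1 and 3, which keep the saturated chain carbon drawn S, stay within the scatter of each other even though their saturated ring carbons differ in configuration. Compound 2, with that chain carbon drawn R, lies apart, an at least 16-fold lower number from compound 2 to compound 3 (1.21 log units; beyond the scatter). The value of compound 2, > 9100 nM, is a limit and not a number.

With only these three compounds, the ring and chain changes in compound 2 cannot be fully separated. As far as these compounds go, whether the chain carbon keeps this weight with an amine in place of its hydroxyl also stays open.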